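The source may hold more compounds than are shown below. What is called first, only, known or untested is meant among the compounds shown, and "the series" means these compounds.

Compound 1, `CCCCCCCCCCCCCCCCCC(=O)NCc1ccc(O)c(OC)c1`: in an assay on HEK293 cells for antagonist activity at transient receptor potential cation channel subfamily V member 2 (Rattus norvegicus), read by fluorescence and calcium flux, with a stated time of 5 min (on this read-out higher numbers stand for weaker inhibition and lower numbers for stronger inhibition), compound 1 gives > 10000 nM, which is a limit of the assay and not a number.
Compound 2, `CCCCCCCCCCCCCCCC(=O)NCc1ccc(O)c(OC)c1`: in this assay compound 2 gives > 10000 nM, again a limit.
Compound 3, `CCCCCCCCCCCCCCCCCCCC(N)=O`: in this assay compound 3 gives > 10000 nM, also a limit.

Compound 3 thus stands at the limit, as do the other two; all three values sit at the limit of > 10000 nM in this assay, at which 3 of the 3 values shown sit, so none of them can be ordered against the others. Among the compounds with values here, the single step among measured compounds that differ in one place, a step that the two limits leave unreadable from compound 1 to compound 2, is left unreadable by the two limits. Compound 4, `CCCCCCCCCCCCCCCCCCCC(=O)NCc1ccc(O)c(OC)c1`, arises from compound 3 by 4-hydroxy-3-methoxybenzyl in place of hydrogen on an amide-type nitrogen. The same 4-hydroxy-3-methoxybenzyl group on the amide-type nitrogen is present in compound 1 and in compound 2, both of which sit at the limit, so the change takes compound 3 into a family whose members have so far given no number. Within the data shown here, no measured step bears readably on this change, and the expectation for compound 4 in this assay is therefore no readable step beyond the scatter, with the value most likely once more reported as a limit. The estimate for compound 4 is 20000 nM, in a range from 5000 nM to 100000 nM. This corresponds to an expected step that the limit leaves unreadable from compound 3 to compound 4.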

Compound 4, half-maximal inhibitory concentration: 3100 nM
The estimate for compound 4 lay 6.5-fold (0.81 log units) above the measured number, and the stated range ends above it.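

Within the data shown here, with the 4-hydroxy-3-methoxybenzyl group in place of hydrogen on the amide-type nitrogen, this assay shows an at least 3.2-fold lower number from compound 3 to compound 4 (0.50 log units; beyond the scatter), the first step that can be read. The group is not enough on its own, since compound 1 and compound 2 carry it as well, and the length of the chain also counts: butyl in place of hydrogen on a saturated chain carbon gives an at least 3.2-fold lower number from compound 2 to compound 4 (0.50 log units; beyond the scatter), and ethyl in the same place gives an at least 3.2-fold lower number from compound 1 to compound 4 (0.50 log units; beyond the scatter). Compound 4 is thus the only one of the four with a number, while the values of compound 1, compound 2 and compound 3 are limits of the assay and not numbers: the limit of > 10000 nM in this assay, at which 3 of the 4 values shown sit.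

On these data alone, whether a longer chain than that of compound 4 lowers the number further, and whether an amine or a carboxylic acid in place of the 4-hydroxy-3-methoxybenzyl group would keep the number readable, stays open. As far as these compounds go, the step between the two limits of compound 1 and compound 2 still cannot be read, so the size of the chain effect below compound 4 remains unknown.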